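Chloro to methyl: what to expect for compound 3

A few compounds are considered here, and "the series" means these few. Any claim that something is new, unique, unknown or untested is made for them only; others in the source may bear on it.

Compound 1 (`Cc1ccc2[nH]c(-c3cn(-c4ccccc4)nc3-c3ccccc3)nc2c1`) gives 5940 nM
Compound 2 (`Clc1ccc(-c2nn(-c3ccccc3)cc2-c2nc3cc(Cl)ccc3[nH]2)cc1`) gives 1170 nM

In a functional assay on MCF7 cells (Homo sapiens) for antiproliferative activity, read by MTT assay, with a stated time of 48 h (a lower number here means a stronger inhibitor, a higher number a weaker inhibitor), compound 2 has the lower of the two numbers (1170 nM) and so is the stronger inhibitor of the pair. Its gap to compound 1 lies beyond the usual scatter. Compound 3 (`Cc1ccc2[nH]c(-c3cn(-c4ccccc4)nc3-c3ccc(Cl)cc3)nc2c1`) differs from compound 2 in one place: methyl in place of chloro on an aromatic carbon. Among the compounds with values here, no measured pair shows this change on its own, so the size of the step can only be judged indirectly. Compound 3 carries this methyl, as does compound 1 (5940 nM), so a moderate rise in the number is expected, pointing to a weaker inhibitor. The expected change is a step (a 2.4-fold higher number from compound 2 to compound 3 (0.38 log units; beyond the scatter)) that probably lies beyond the scatter. For compound 3 the estimated value is 2800 nM with a likely range (1100 nM to 7000 nM).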

Compound 3, half-maximal inhibitory concentration: 8230 nM
Compound 3: middle estimate off by 2.9-fold (0.47 log units), on the low side; the measured number lies above the stated range.
By their numbers in this assay, from the lowest: compound 2; then compounds 1 and 3 (each within the scatter of the next).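

In this assay, methyl in place of chloro on this carbon of the fused system gives a 7.0-fold higher number from compound 2 to compound 3 (0.85 log units; beyond the scatter), so this one-atom swap by itself produces a step beyond the scatter. Chloro in place of hydrogen on an aromatic carbon gives a 1.4-fold higher number from compound 1 to compound 3 (0.14 log units; within the scatter), so when the methyl is present, adding that chloro makes no readable difference. No measurement available here explains why the swap at the fused system matters so much more.

The compounds shown leave open how other groups on this carbon would compare, such as fluoro, methoxy or an amine, and whether hydrogen there would sit closer to methyl or to chloro. They also leave open whether the second chloro of compound 2 contributes anything when the chloro on the fused system is kept.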